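Three Esters Hold in Buffer; a Fourth Is Awaited

This account rests on a few compounds, and the source may have more. Where it says the series, first, only, none or still open, it means among the compounds named here.

Three esters of one shared core have been run through a physicochemical assay for metabolic stability, read by LC-MS, in phosphate buffer, with a stated time of 3 h, at pH 7.4, tested at 50 uM; a higher number here means that more of the compound is left, a lower number that less of the compound is left. Compound 1 `Cc1oc(=O)oc1COC(=O)c1cccc(NC(=O)[C@@H]2C[C@H](SC3=C(C(=O)O)N4C(=O)[C@H]([C@@H](C)O)[C@H]4[C@H]3C)CN2)c1` gives > 95% in this assay, which is a limit of the assay and not a number. Compound 2 `CC(C)OC(=O)c1cccc(NC(=O)[C@@H]2C[C@H](SC3=C(C(=O)O)N4C(=O)[C@H]([C@@H](C)O)[C@H]4[C@H]3C)CN2)c1`, the isopropyl ester, gives > 95%, again a limit. Compound 3 `C[C@@H](O)[C@H]1C(=O)N2C(C(=O)O)=C(S[C@@H]3CN[C@H](C(=O)Nc4cccc(C(=O)OCOC(=O)C(C)(C)C)c4)C3)[C@H](C)[C@H]12`, the (((tert-butyl)carbonyl)oxy)methyl ester, gives > 95%, also a limit. The steps between them, a step that the two limits leave unreadable from compound 1 to compound 2, a step that the two limits leave unreadable from compound 1 to compound 3 and a step that the two limits leave unreadable from compound 2 to compound 3, cannot be read in size because of the limit of > 95% in this assay, at which 3 of the 3 values shown sit. Compound 3 thus stands at the limit together with the other two, and nothing separates it from them on the numbers shown.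

Compound 4 `CC(C)C(=O)OCOC(=O)c1cccc(NC(=O)[C@@H]2C[C@H](SC3=C(C(=O)O)N4C(=O)[C@H]([C@@H](C)O)[C@H]4[C@H]3C)CN2)c1` differs from compound 3 by hydrogen in place of methyl on a saturated chain carbon bound to a carbonyl carbon and two saturated chain carbons. Going by the values given here, the steps that bear on this change are those ending on compound 3, a step that the two limits leave unreadable from compound 1 to compound 3 and a step that the two limits leave unreadable from compound 2 to compound 3, and neither yields a readable size; across the three esters no value has yet moved off the limit. The expected step is therefore a step that the limit leaves unreadable from compound 3 to compound 4, none beyond the scatter, with the result most likely reported once more as a limit. Compound 4 is estimated at 97%, within a range from 88% to 100%.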

Compound 4, percent of the compound remaining: > 95%
Compound 4 gave a limit, no number; the forecaster's own chance of this, stated with the estimate: 85%; the middle value is on the limit's open side.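

In this assay compound 4 gives > 95%, a limit and not a number. The steps to compound 4 from compound 1, compound 2 and compound 3 cannot be read in size because of one shared limit: the limit of > 95% in this assay, at which 4 of the 4 values shown sit. The compounds shown leave open whether any of these four esters differs from the others in the percent of compound remaining.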